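Hydroxylated Bicyclic Amine Replacing Hydroxycyclohexyl on the Amide

The compounds below may be only part of what the source reports. "The series", "measured", "known", "first", "only" and "open" are said of these compounds alone.

Measured so far:
Compound 1, `CNC(=O)c1cc(C(=O)N[C@H]2[C@@H]3COC[C@@H]32)c([C@@H](C)c2ccccc2)o1`: 100%
Compound 2, `CNC(=O)c1cc(C(=O)N[C@H]2CC[C@H](O)CC2)c([C@@H](C)c2ccccc2)o1`: 84%

In an ADME assay on the whole organism (Canis lupus familiaris, strain Beagle) for pharmacokinetics, read by LC-MS, with a stated time of 7 h, at a dose of 1 mg/kg by the oral route (a higher number here means that a larger share of the oral dose reaches the circulation, a lower number that a smaller share of the oral dose reaches the circulation), compound 2 gives 84%, the lower of the two numbers; compound 1 gives 100%. Compound 3, `CNC(=O)c1cc(C(=O)N[C@H]2[C@@H]3C[C@@H](O)C[C@@H]32)c([C@@H](C)c2ccccc2)o1`, differs from compound 2 in one place: a group of 7 heavy atoms (6 carbon, 1 oxygen; one three-membered non-aromatic ring of carbon only, one five-membered non-aromatic ring of carbon only) in place of a group of 7 heavy atoms (6 carbon, 1 oxygen; one six-membered non-aromatic ring of carbon only), on an amide-type nitrogen. Among the compounds with values here, the only step that bears on this is a number 16 percentage points lower from compound 1 to compound 2 (beyond the scatter), which also exchanged the group on that amide nitrogen: a group with a three-membered and a five-membered ring scored higher than one with a six-membered ring. Compound 3 brings a three-membered and a five-membered ring back, now carrying a hydroxyl. A small rise, within the scatter, is therefore expected: a number 6 percentage points higher from compound 2 to compound 3 (within the scatter). Compound 3 is estimated at 90%, ranging from 70% to 100%.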

Compound 3, oral bioavailability: 58%
Compound 3: middle estimate off by 32 percentage points, on the high side; the measured number lies below the stated range.
By their numbers in this assay, from the lowest: compound 3; then compound 2; then compound 1.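

In this assay, the pairing of a three-membered and a five-membered ring on the amide-type nitrogen does not by itself give the higher number: the result is a number 26 percentage points lower from compound 2 to compound 3 (beyond the scatter), although the leaving and entering groups have equal heavy-atom, donor and acceptor counts. Within the data shown here, with both ring sizes kept, replacing the oxygen-containing five-membered ring with a hydroxyl-bearing carbon-only one gives a number 42 percentage points lower from compound 1 to compound 3 (beyond the scatter). Nothing measured here accounts for either drop. As far as these compounds go, whether the hydroxyl or the carbon-only ring matters more remains open, as does how an amine or a methoxy group on that ring pair would read.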